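A few compounds are considered here, and "the series" means these few. Any claim that something is new, unique, unknown or untested is made for them only; others in the source may bear on it.

Measured so far:
compound 1, `Cc1cc(C)c(S(=O)(=O)N2CCN(C3CN4CCC3CC4)CC2)c(C)c1`, 84 nM in a functional assay on DLD-1 cells (Homo sapiens) for antiproliferative activity, read by CellTiter-Glo, with a stated time of 72 h; a higher number here means a weaker inhibitor, a lower number a stronger inhibitor
compound 2, `Cc1cc(C)c(S(=O)(=O)N2CCC(N3CCC(c4ccccc4)CC3)CC2)c(C)c1`, 865 nM
compound 3, `Cc1cc(S(=O)(=O)N2CCC(N3CCC(C)CC3)CC2)c(Cl)cc1Cl`, 2 nM

Compound 2 stands at the highest of the three numbers in this assay. Its nearest neighbour is compound 1, whose number is lower by a margin beyond the scatter; compound 3 lies furthest away, with a much lower number, again beyond the scatter.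

Compound 4, `Cc1cc(C)c(S(=O)(=O)N2CCC(N3CCC(Cc4ccccc4F)CC3)CC2)c(C)c1`, differs from compound 2 in one place: 2-fluorobenzyl in place of phenyl on a saturated ring carbon. For the measured compounds named here, no measured pair shows this change, so its size is open. The expected step of a 1.4-fold lower number from compound 2 to compound 4 (0.16 log units; within the scatter) is small, most likely within the scatter, with a wide band on either side. Compound 4 is accordingly estimated at 600 nM, within 150 nM to 2500 nM.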

Compound 4, half-maximal inhibitory concentration: 74 nM
Compound 4: the middle estimate sits 8.1-fold (0.91 log units) above what was measured; measured number outside the range, below it.
By their numbers in this assay, from the lowest: compound 3; then compounds 4 and 1 (each within the scatter of the next); then compound 2.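

In this assay the saturated ring carbon three ring bonds from the ring nitrogen proves sensitive to the group it carries: 2-fluorobenzyl in place of phenyl gives a 12-fold lower number from compound 2 to compound 4 (1.07 log units; beyond the scatter) with no other change to the molecule. For the compounds shown here, this is the first step read at this position, and it shows that the large group there can shift the number substantially. Nothing at hand accounts for the size of this step.

Going by these compounds, whether the step follows the fluorine or the added carbon stays open, and unsubstituted benzyl would separate the two. On these data alone, how an amine or a carboxylic acid at this ring carbon would compare is also open.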